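A few compounds are considered here, and "the series" means these few. Any claim that something is new, unique, unknown or untested is made for them only; others in the source may bear on it.

Of the compounds shown here, three of a shared core have been measured in a functional assay, read by spectrophotometry, with a stated time of 3 min; a lower number here means a stronger inhibitor, a higher number a weaker inhibitor. Compound 1 `O=c1[nH]c2ccccc2cc1/C=N/CCO` gives 1210000 nM in this assay, compound 2 `CCCC/N=C/c1cc2ccccc2[nH]c1=O` gives 1810000 nM, and compound 3 `Cc1ccc2[nH]c(=O)c(/C=N/Cc3ccccc3)cc2c1` gives 607000 nM. Compound 3 shows the lowest of the three numbers; its nearest neighbour is compound 1, whose number lies within the scatter of it, while compound 2 lies beyond the scatter. Within the data shown here, the only step between measured compounds, a 1.5-fold higher number from compound 1 to compound 2 (0.17 log units; within the scatter), concerns a saturated chain carbon and says nothing about the ring.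

Compound 4 `O=c1[nH]c2ccccc2cc1/C=N/Cc1ccccc1` differs from compound 3 by hydrogen in place of methyl on an aromatic carbon, on an aromatic carbon of a six-membered aromatic ring of carbon only, part of a fused system of two rings. Among the measured compounds shown here, no measured step touches this position, so nothing in the data predicts a shift beyond the scatter. Compound 4 is therefore expected to give about 700000 nM in this assay, in the range 300000 nM to 1600000 nM. The expected step of a 1.2-fold higher number from compound 3 to compound 4 (0.06 log units; within the scatter) is essentially none.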

Compound 4, half-maximal inhibitory concentration: 368000 nM
For compound 4 the middle estimate is 1.9-fold (0.28 log units) above the measured one, within the range that was stated.
By their numbers in this assay, from the lowest: compounds 4, 3, 1 and 2 (each within the scatter of the next, the first and the last beyond it).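

In this assay, hydrogen in place of methyl on this aromatic carbon of the fused system gives a 1.6-fold lower number from compound 3 to compound 4 (0.22 log units; within the scatter), so the methyl group is not needed to hold the number at this level. Compound 4 also allows the chain ends to be compared on the same core: phenyl in place of propyl gives a 4.9-fold lower number from compound 2 to compound 4 (0.69 log units; beyond the scatter), and phenyl in place of hydroxymethyl gives a 3.3-fold lower number from compound 1 to compound 4 (0.52 log units; beyond the scatter), whereas the earlier step from hydroxy to ethyl stayed within the scatter. Nothing available explains these shifts.

As far as these compounds go, whether methoxy or chlorine on this aromatic carbon would move the number beyond the scatter stays open. Also open, from the compounds shown here alone, is what an amine or a carboxylic acid on the phenyl ring of compound 4 would do.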